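The source may hold more compounds than are shown below. What is called first, only, known or untested is meant among the compounds shown, and "the series" means these compounds.

In an assay for inhibition of hexokinase-2 (Homo sapiens), read by coupled enzyme assay, with a stated time of 10 min, in the presence of a further agent that is not named here (on this read-out lower numbers stand for stronger inhibition and higher numbers for weaker inhibition), compound 1 `C=C1CC[C@H]2[C@@](C)(CCC(=O)N[C@@]2(C)COC(=O)[C@@H]2CCCN2)[C@@H]1/C=C/C1=CCOC1=O` gives > 50000 nM, which is a limit of the assay and not a number. Compound 2 `C=C1CC[C@H]2[C@@](C)(CC[C@@H](O)[C@@]2(C)NC=O)[C@@H]1/C=C/C1=CCOC1=O` gives > 50000 nM in this assay, again a limit. Compound 3 `C=C1CC[C@H]2[C@@](C)(CC[C@@H](OC(=O)c3cccnc3)[C@@]2(C)NC=O)[C@@H]1/C=C/C1=CCOC1=O` gives > 50000 nM in this assay, a limit as well. The only single-point step among these, (pyridin-3-yl)carbonyl in place of hydrogen on an oxygen on a saturated carbon, is a step that the two limits leave unreadable from compound 2 to compound 3, so its size cannot be read. Compound 3 therefore stands where all three measured values stand: at the limit, as the limit of > 50000 nM in this assay, at which 3 of the 3 values shown sit, records.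

Compound 4 `C=C1CC[C@H]2[C@@](C)(CC[C@@H](OC(=O)c3ccccc3)[C@@]2(C)NC=O)[C@@H]1/C=C/C1=CCOC1=O` differs from compound 3 by phenyl in place of pyridin-3-yl on a carbonyl carbon, which is phenyl in place of pyridin-3-yl on a carbonyl carbon. Among the measured compounds shown here, no measured step bears directly on this change, and the one step that comes nearest was unreadable between two limits. Compound 4 is therefore expected to show a step that the limit leaves unreadable from compound 3 to compound 4, with the value most likely again falling at the limit. Compound 4 is estimated at 80000 nM, within a range from 30000 nM to 200000 nM.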

Compound 4, half-maximal inhibitory concentration: > 50000 nM
Compound 4: no number, only a limit; the forecaster's own chance of this, stated with the estimate: 85%; the middle value does not contradict the limit.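

In this assay compound 4 gives > 50000 nM, which is a limit of the assay and not a number. No new step can be read from compound 2 or compound 3 to compound 4. The compounds shown leave open which structural change, if any, would bring a measurable value, and every result stands at one place: the limit of > 50000 nM in this assay, at which 4 of the 4 values shown sit.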